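The source may report more compounds than this note shows. Statements on the series, on what has been measured and on what is new or still open speak of the compounds shown alone.

Working notes on a series of oligothiophenes carrying short chains at the outer rings. Compound 1 `BrCCCCc1ccc(-c2ccc(-c3ccc(-c4ccc(CCCCBr)s4)s3)s2)s1` carries two 4-bromobutyl chains at the outer rings of the core; in an ADME assay on MDCK cells (Canis lupus familiaris) for cytotoxicity, read by MTT assay, with a stated time of 2 days (a lower number here means that less compound is tolerated, a higher number that more compound is tolerated), compound 1 stands as "not determined" (no result reported), so it has no reported number. Two neighbours in the series have been read. Compound 2 `NCCCc1ccc(-c2ccc(-c3ccc(-c4cccs4)s3)s2)s1`, with a single 3-aminopropyl chain, reaches only a limit of the assay in this assay, giving > 200000 nM. Compound 3 `NCCCCc1ccc(-c2ccc(-c3ccc(CCCCN)s3)s2)s1`, with two 4-aminobutyl chains on a shorter core, gives 13000 nM in this assay. Of the three values shown, one sits at the limit (the limit of > 200000 nM in this assay, at which 1 of the 3 values shown sits).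

Compound 4 `BrCCCCc1ccc(-c2ccc(-c3cccs3)s2)s1` is the next member to be read. It differs from compound 1 in one place: hydrogen in place of 5-(4-bromobutyl)thiophen-2-yl on an aromatic carbon. For the measured compounds named here, since compound 1 has no number in this assay, no step from compound 1 to compound 4 can be sized or given a direction in this assay; the only anchors are the number of compound 3 and the limit reached by compound 2. With a shorter core and one bromobutyl chain left, compound 4 is expected to sit between those two anchors in this assay, with the estimate placed at 50000 nM, ranging from 8000 nM to 200000 nM.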

Compound 4, half-maximal cytotoxic concentration: 23800 nM
The estimate for compound 4 lay 2.1-fold (0.32 log units) above the measured number, and the stated range covers the measured number.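

With no number for compound 1 in this assay, the step from compound 1 to compound 4 cannot be read, in size or in direction. The compounds shown leave open how replacing 5-(4-bromobutyl)thiophen-2-yl with hydrogen alters tolerance, and what number compound 2 would take, since its reading is a limit: the limit of > 200000 nM in this assay, at which 1 of the 4 values shown sits.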